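This account rests on a few compounds, and the source may have more. Where it says the series, first, only, none or still open, it means among the compounds named here.

Measured so far in a functional assay on 1321-N1 cells for agonist activity at P2Y purinoceptor 2 (Homo sapiens), read by scintillation counting and inositol phosphate accumulation; on this read-out lower numbers stand for an effect already at smaller amounts and higher numbers for an effect only at larger amounts of compound:
- compound 1 `O=C(O)CCCO/N=c1/ccn([C@@H]2O[C@H](COP(=O)(O)OP(=O)(O)OP(=O)(O)O)[C@@H](O)[C@H]2O)c(=O)[nH]1`: 299 nM
- compound 2 `O=c1[nH]/c(=N\OCCCc2cccc(F)c2)ccn1[C@@H]1O[C@H](COP(=O)(O)OP(=O)(O)OP(=O)(O)O)[C@@H](O)[C@H]1O`: 190 nM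
- compound 3 `O=c1[nH]/c(=N\OCCCc2ccncc2)ccn1[C@@H]1O[C@H](COP(=O)(O)OP(=O)(O)OP(=O)(O)O)[C@@H](O)[C@H]1O`: 285 nM

Compound 1 gives the highest number of the three, yet this standing carries little weight because a 1.6-fold lower number from compound 1 to compound 2 (0.20 log units; within the scatter) and a 1.0-fold lower number from compound 1 to compound 3 (0.02 log units; within the scatter) both sit within the scatter. Compound 4 `O=c1[nH]/c(=N\OCCCc2ccsc2)ccn1[C@@H]1O[C@H](COP(=O)(O)OP(=O)(O)OP(=O)(O)O)[C@@H](O)[C@H]1O` is the next step from compound 1: thiophen-3-yl in place of carboxy on a saturated chain carbon, three bonds along the chain from an oxygen on an unsaturated carbon. Two earlier steps bear on it, each replacing carboxy at the same place with an aromatic ring, and neither moved the number beyond the scatter. A thiophen-3-yl ring at that place is therefore expected to behave alike, with no step beyond the scatter in this assay. Compound 4 is thus estimated at 250 nM (range 120 nM to 550 nM), the expected step being a 1.2-fold lower number from compound 1 to compound 4 (0.08 log units; within the scatter).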

Compound 4, half-maximal effective concentration: 103 nM
Compound 4: the middle estimate sits 2.4-fold (0.39 log units) above what was measured, outside the stated range (below it).
By their numbers in this assay, from the lowest: compounds 4, 2, 3 and 1 (each within the scatter of the next, the first and the last beyond it).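

In this assay, within the data shown here, the saturated chain carbon proves responsive to what it carries: thiophen-3-yl gives a 2.9-fold lower number from compound 1 to compound 4 (0.46 log units; beyond the scatter) in place of carboxy and a 2.8-fold lower number from compound 3 to compound 4 (0.44 log units; beyond the scatter) in place of pyridin-4-yl , the first steps here beyond the scatter, so aromatic rings at this place do not all behave alike. In place of 3-fluorophenyl it gives a 1.8-fold lower number from compound 2 to compound 4 (0.27 log units; within the scatter), so these two rings cannot be told apart. No available evidence accounts for these differences. Still open, on these data alone, is whether an unsubstituted phenyl, a thiophen-2-yl ring or a longer chain carrying thiophen-3-yl would give a similar number.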